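Iodo to methoxy in the growth-inhibition series

The source may hold more compounds than are shown below. What is called first, only, known or untested is meant among the compounds shown, and "the series" means these compounds.

Compound 1 `NC(=O)c1cc(Cl)ccc1NC(=O)COc1ccccc1` gives 8150 nM
Compound 2 `NC(=O)c1cc(I)ccc1NC(=O)COc1ccccc1` gives 3170 nM
Compound 3 `COc1ccc(NC(=O)COc2ccccc2)c(C(N)=O)c1` is not yet measured

In a functional assay on SK-OV-3 cells (Homo sapiens) for inhibition (a higher number here means a weaker inhibitor of growth, a lower number a stronger inhibitor of growth), compound 2 has the lower of the two numbers at 3170 nM so far. Compound 3 differs from compound 2 by methoxy in place of iodo on an aromatic carbon on an aromatic carbon, meta to a carbamoyl group and para to a large group. Within the data shown here, the only measured step is a 2.6-fold lower number from compound 1 to compound 2 (0.41 log units; beyond the scatter) and it concerns chloro and iodo, so it bears only loosely on methoxy. A modest step of similar size toward a higher number is expected, and the estimate is a 2.5-fold higher number from compound 2 to compound 3 (0.40 log units; beyond the scatter) with wide uncertainty. Compound 3 is expected at 8000 nM with 3000 nM to 22000 nM as the estimated range.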

Compound 3, concentration for 50% growth inhibition: 2990 nM
Compound 3: middle estimate off by 2.7-fold (0.43 log units), on the high side; the whole stated range lies above it.
By their numbers in this assay, from the lowest: compounds 3 and 2 (each within the scatter of the next); then compound 1.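

In this assay, the step of a 1.1-fold lower number from compound 2 to compound 3 (0.03 log units; within the scatter) shows that iodo and methoxy on this aromatic carbon, para to a large group, are not told apart, although one iodine gives way to a carbon and an oxygen with one hydrogen-bond acceptor. Methoxy in place of chloro gives a 2.7-fold lower number from compound 1 to compound 3 (0.44 log units; beyond the scatter), so among these three groups compound 1 alone stands apart.

As far as these compounds go, whether an amine, a carboxylic acid or a longer alkoxy chain at this position would stay level with compound 2 and compound 3 remains open. No supporting data bear on what lies behind this result.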